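This account rests on a few compounds, and the source may have more. Where it says the series, first, only, none or still open, it means among the compounds named here.

Measured compounds:

Compound 1, `CCn1nnc(-c2sc(-c3cccc(C)c3)nc2O)n1`, gives 369 nM in an assay on HEK293 cells for inhibition of transient receptor potential cation channel subfamily M member 8 (Homo sapiens), read by FLIPR, with stated times of 5 min and 3 min; a lower number here means a stronger inhibitor, a higher number a weaker inhibitor.
Compound 2, `CCNC(=O)c1sc(-c2ccccc2)nc1O`, gives > 100000 nM in this assay, a limit of the assay rather than a number.
Compound 3, `Oc1nc(-c2cccc(F)c2)sc1-c1nn[nH]n1`, also gives > 100000 nM in this assay, likewise a limit.

All three compounds share one core, and they differ in the group carried on it. Compound 1 is the only one of the three for which this assay returns a number. Compound 2 stands at the limit of > 100000 nM in this assay, at which 2 of the 3 values shown sit, so what is known of it is only that it shows no measurable inhibition up to that limit. Compound 4, `CCN(C)C(=O)c1sc(-c2ccccc2)nc1O`, is the compound not yet measured; it differs from compound 2 by methyl in place of hydrogen on an amide-type nitrogen. Among the measured compounds shown here, no pair of measured compounds differs in this one place, so there is no measured step to lean on for this change. With compound 2 sitting at a limit, the step from compound 2 to compound 4 is expected to be a number no higher from compound 2 to compound 4 (the limit leaves the size open), that is, essentially none beyond the scatter. Compound 4 is therefore expected to give 100000 nM, within a range from 20000 nM to 300000 nM, and most likely to come back as a limit again.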

Compound 4, half-maximal inhibitory concentration: 6400 nM
Compound 4: middle estimate off by 16-fold (1.19 log units), on the high side; the whole stated range lies above it.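

In this assay there is an at least 15-fold lower number from compound 2 to compound 4 (1.19 log units; beyond the scatter) when methyl replaces hydrogen on an amide-type nitrogen, so a single added carbon at this place is enough to turn a compound with no number into one with a number. Among the compounds shown here, this is the only measured step at this place, and it shows that the change from ethylcarbamoyl to ethyl(methyl)carbamoyl matters far more than the earlier compounds could reveal, since none of them formed a pair differing in one place. The size of the step is a floor rather than an exact figure, because compound 2 has only a limit and no number of its own: the limit of > 100000 nM in this assay, at which 2 of the 4 values shown sit.

The compounds shown leave open whether methyl is special at this nitrogen, or whether a longer chain such as propyl or a branched group such as isopropyl would give a similar or larger step. Also open, as far as these compounds go, is whether inhibition would survive with an amine or a carboxylic acid placed at the end of the ethyl chain.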